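This account rests on a few compounds, and the source may have more. Where it says the series, first, only, none or still open, it means among the compounds named here.

The measured compounds:
Compound 1 `CC1=C(C(=O)C2CC2)C(c2ccco2)NC(=O)N1`: in an assay on membranes from CHO cells for displacement of a labelled ligand from adenosine receptor A1 (Homo sapiens), read by scintillation counting, with a stated time of 60 min, tested at 1 uM (on this read-out lower numbers stand for less inhibition and higher numbers for more inhibition at the one concentration tested (going by the name of the read-out)), compound 1 gives 2%.
Compound 2 `CCCC(=O)C1=C(C)NC(=O)NC1c1ccco1`: in this assay compound 2 gives 1%.
Compound 3 `CCNC(=O)C1=C(C)NC(=O)NC1c1ccco1`: in this assay compound 3 gives 2%.

Compound 3 stands level with compound 1 at the digits shown, and the two together hold the highest of the three numbers, yet all three are small and none differs from another beyond the scatter: the step from compound 1 to compound 3 is no change at the digits printed from compound 1 to compound 3 (within the scatter), and the step from compound 2 to compound 3 is a number 1 percentage points higher from compound 2 to compound 3 (within the scatter).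

Compound 4 `CCN(CC)C(=O)C1=C(C)NC(=O)NC1c1ccco1` differs from compound 3 by ethyl in place of hydrogen on an amide-type nitrogen; taken one bond further out, ethylamino becomes diethylamino. Within the data shown here, none of the measured steps touches this amide-type nitrogen, so they bear on it only loosely. What they show is that swapping the group on the carbonyl carbon, cyclopropyl to propyl (a number 1 percentage points lower from compound 1 to compound 2 (within the scatter)) or cyclopropyl to ethylamino (no change at the digits printed from compound 1 to compound 3 (within the scatter)), leaves the number flat at a low level. On that basis the added ethyl is expected to make no difference beyond the scatter, so the step from compound 3 to compound 4 is estimated as no change at the digits printed from compound 3 to compound 4 (within the scatter). Compound 4 is therefore expected to give 2%, in a range from -5% to 10%.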

Compound 4, a percentage reported as inhibition, at one concentration (the size of the read-out at that concentration, not a potency): 11%
Compound 4: middle estimate off by 9 percentage points, on the low side, and the stated range ends below it.
By their numbers in this assay, from the lowest: compounds 2, 1, 3 and 4 (each within the scatter of the next).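

Ethyl in place of hydrogen on the amide-type nitrogen, which turns ethylamino into diethylamino, is the first change at this nitrogen among these compounds, and in this assay it gives a number 9 percentage points higher from compound 3 to compound 4 (within the scatter) on the shared core. Diethylamino in place of propyl on the carbonyl carbon gives a number 10 percentage points higher from compound 2 to compound 4 (within the scatter) and diethylamino in place of cyclopropyl gives a number 9 percentage points higher from compound 1 to compound 4 (within the scatter), so this change at the nitrogen, like the earlier swaps on the carbonyl carbon, cannot be told apart from the ordinary spread of repeated measurements. Nothing available here offers an explanation for these numbers.

From the compounds shown here alone, it remains open whether a longer chain on this nitrogen, as in dipropylamino, or a ring such as piperidine in place of diethylamino would give a number beyond the scatter. Also open is how any of these compounds would behave at other concentrations, as a reading at one concentration gives no potency.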